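Removing One Chloro Group from a Dichlorinated Core

The source may hold more compounds than are shown below. What is called first, only, known or untested is meant among the compounds shown, and "the series" means these compounds.

Compound 1, `O=c1c(-c2nn[nH]n2)c[nH]c2c(Cl)c(Cl)ccc12`: in a functional assay on the whole organism (strain Sprague-Dawley) for inhibition, with Rattus norvegicus as the target (on this read-out higher numbers stand for an effect only at larger amounts of compound and lower numbers for an effect already at smaller amounts), compound 1 gives > 0.156 mg/kg, which is a limit of the assay and not a number.
Compound 2, `CCCCc1ccc2ncc(-c3nn[nH]n3)cc2c1`: in this assay compound 2 gives 5 mg/kg.
Compound 3, `O=C(O)c1cnc2c(F)cc(F)cc2c1`: in this assay compound 3 gives 25 mg/kg.

Of the compounds shown here, three have been measured so far. Compound 1 stands apart from the other two: for it only a limit is known, (the limit of > 0.156 mg/kg in this assay, at which 1 of the 3 values shown sits), so its place among the numbers is open. Going by the values given here, compound 2 and compound 3 carry different cores, and no single change links either of them to compound 1, so no measured pair differs in just one place.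

Compound 4, `O=c1c(-c2nn[nH]n2)c[nH]c2c(Cl)cccc12`, differs from compound 1 in one place: hydrogen in place of chloro on an aromatic carbon. Among the compounds with values here, since no measured step of one change is available, the size of this step in this assay cannot be read from the numbers. The expectation is a modest step toward a larger dose, possibly beyond the scatter, that is a step that the limit leaves unreadable from compound 1 to compound 4. Compound 4 is therefore expected to give about 1 mg/kg in this assay, estimated to fall between 0.2 mg/kg and 8 mg/kg.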

Compound 4, minimum effective dose: 0.078 mg/kg
The estimate for compound 4 lay 13-fold (1.11 log units) above the measured number; the measured number lies below the stated range.
By their numbers in this assay, from the lowest: compound 4; then compound 2; then compound 3.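

Going by these compounds alone, this is the first step of a single change available here, and it gives a direction: in this assay, hydrogen in place of chloro on an aromatic carbon, ortho to a chloro group, goes with an at least 2.0-fold lower number from compound 1 to compound 4 (0.30 log units; that floor lies within the scatter). Compound 4, at 0.078 mg/kg, shows that this chloro group is not needed for an effect at a small dose. The true size of the step cannot be read, because compound 1 is known only through a value that is a limit of the assay and not a number: the limit of > 0.156 mg/kg in this assay, at which 1 of the 4 values shown sits.

From the compounds shown here alone, whether a methyl or a methoxy group at this same place would keep so small a dose remains open. The compounds shown also leave open what happens to the dose when the remaining chloro group gives way to hydrogen.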